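Ester variants of a hydroxamate series on prostate carcinoma cells

This account rests on a few compounds, and the source may have more. Where it says the series, first, only, none or still open, it means among the compounds named here.

Measured compounds:
compound 1 `CC[C@H](C)C(=O)O[C@H]1C[C@@H](C)C=C2C=C[C@H](C)[C@H](CC[C@@H](O)C[C@@H](CC(=O)NO)OC(=O)C(C)(C)C)[C@H]21` — 7200 nM
compound 2 `CC[C@H](C)C(=O)O[C@H]1C[C@@H](C)C=C2C=C[C@H](C)[C@H](CC[C@@H](O)C[C@@H](CC(=O)NO)OC(=O)c3ccc(Cl)cc3)[C@H]21` — 21700 nM

In a functional assay on PC-3 cells (Homo sapiens) for inhibition, read by sulforhodamine B assay, with a stated time of 48 h (on this read-out higher numbers stand for weaker inhibition and lower numbers for stronger inhibition), compound 1 gives 7200 nM. Compound 2 sits at the higher of the two numbers: the change from compound 1 to compound 2 went a 3.0-fold higher number from compound 1 to compound 2 (0.48 log units; beyond the scatter), so compound 2 is the weaker of the pair in this assay.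

Compound 3 `CC[C@H](C)C(=O)O[C@H]1C[C@@H](C)C=C2C=C[C@H](C)[C@H](CC[C@@H](O)C[C@@H](CC(=O)NO)OC(=O)c3ccc4ccccc4c3)[C@H]21` has not yet been measured. It differs from compound 2 by naphthalen-2-yl in place of 4-chlorophenyl on a carbonyl carbon. Within the data shown here, the only measured step touching this position, a 3.0-fold higher number from compound 1 to compound 2 (0.48 log units; beyond the scatter), swapped an alkyl for an aryl group and does not cover an aryl-to-aryl exchange, so no direct precedent exists for it. Given that the sole step at this carbonyl carbon moved toward weaker inhibition, and with no counter-example, a small further weakening or no change beyond the scatter is expected, a step of a 1.2-fold higher number from compound 2 to compound 3 (0.08 log units; within the scatter). Compound 3 is therefore estimated at 26000 nM, within 9000 nM to 75000 nM.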

Compound 3, half-maximal inhibitory concentration: 17300 nM
Estimate against measurement, compound 3: 1.5-fold (0.18 log units) above; measured number inside the range.
By their numbers in this assay, from the lowest: compound 1; then compounds 3 and 2 (each within the scatter of the next).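

In this assay, the exchange of 4-chlorophenyl for naphthalen-2-yl on this carbonyl carbon gives a 1.3-fold lower number from compound 2 to compound 3 (0.10 log units; within the scatter), so the two aryl groups cannot be told apart on this read-out. Placing naphthalen-2-yl where compound 1 carries tert-butyl gives a 2.4-fold higher number from compound 1 to compound 3 (0.38 log units; beyond the scatter), which makes compound 1 the strongest of the three and sets both aryl esters apart from it. Nothing available accounts for this separation.

A straight butyl chain or a cyclohexyl group on this carbonyl carbon would test whether the lower number belongs to tert-butyl alone or to alkyl groups more widely. A phenyl ring carrying an amine would show whether any aryl ester can come back to the level of compound 1.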